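The compounds below may be only part of what the source reports. "The series", "measured", "known", "first", "only" and "open" are said of these compounds alone.

Compound 1, `Cc1ccc(-c2c(C)[nH]c(=O)n2C)cc1`: in a functional assay on brain (Rattus norvegicus, strain Wistar) for inhibition (on this read-out lower numbers stand for stronger inhibition and higher numbers for weaker inhibition), compound 1 gives 85300 nM.
Compound 2, `Cc1[nH]c(=O)n(C)c1-c1ccc(OCCC(C)C)cc1`: compound 2 gives 6600 nM.
Compound 3, `Cc1[nH]c(=O)n(C)c1-c1ccc(Oc2ccccc2)cc1`: compound 3 gives 8100 nM.

Among these three numbers compound 3 stands second highest, within the scatter of compound 2 and far from compound 1. The steps of a 13-fold lower number from compound 1 to compound 2 (1.11 log units; beyond the scatter) and an 11-fold lower number from compound 1 to compound 3 (1.02 log units; beyond the scatter) were large, whereas a 1.2-fold higher number from compound 2 to compound 3 (0.09 log units; within the scatter) lay within the scatter.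

Compound 4, `Cc1[nH]c(=O)n(C2CCCCC2)c1-c1ccc(Oc2ccccc2)cc1`, differs from compound 3 by cyclohexyl in place of methyl on an aromatic nitrogen. Going by the values given here, none of the measured steps touches the group on the aromatic nitrogen; all three concern the group on the aromatic carbon of the pendant ring. The measured steps therefore give no direct guide, and the step is expected to stay within the scatter, a 1.0-fold lower number from compound 3 to compound 4 (0.01 log units; within the scatter). Compound 4 is estimated at 8000 nM, with a range from 2000 nM to 32000 nM.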

Compound 4, half-maximal inhibitory concentration: 7900 nM
Compound 4: the middle estimate sits 1.0-fold (0.01 log units) above what was measured, and the stated range covers the measured number.
By their numbers in this assay, from the lowest: compounds 2, 4 and 3 (each within the scatter of the next); then compound 1.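

In this assay, going by these compounds alone, the earlier steps never touched the aromatic nitrogen, and cyclohexyl in place of methyl there gave a step within the scatter (a 1.0-fold lower number from compound 3 to compound 4 (0.01 log units; within the scatter)). With the phenoxy group in place, this position therefore accepts a six-membered non-aromatic ring of carbon only without a change in the read-out beyond the scatter. No evidence at hand bears on this result.

As far as these compounds go, whether a piperidine or a chain ending in a carboxylic acid on this nitrogen would give a similar number stays open. So does whether cyclohexyl would behave alike alongside the isopentyloxy group of compound 2.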